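The compounds below may be only part of what the source reports. "The series", "measured", "known", "first", "only" and "open" are said of these compounds alone.

Measured compounds in an assay on isolated protein for binding affinity to Gonadotropin-releasing hormone receptor (Homo sapiens); on this read-out lower numbers stand for stronger inhibition and higher numbers for weaker inhibition:
Compound 1, `CCOC(=O)[C@H]1CC[C@H](CNC(=O)c2ccc(Cc3cc4c(cc3C)C(C)(C)CCC4(C)C)o2)CC1`: 51 nM
Compound 2, `Cc1ccc(CNC(=O)c2ccc(Cc3cc4c(cc3C)C(C)(C)CCC4(C)C)o2)cc1`: 83 nM
Compound 3, `Cc1cc2c(cc1Cc1ccc(C(=O)NCC3CCC(CNC(=O)C(F)(F)F)CC3)o1)C(C)(C)CCC2(C)C`: 66 nM

Compound 2 gives the highest of the three numbers in this assay, but its nearest neighbour, compound 3, and its furthest, compound 1, both sit within the scatter of it, so no ordering among the three can be claimed.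

Compound 4, `Cc1cc2c(cc1Cc1ccc(C(=O)NCC3CCCC(CN)C3)o1)C(C)(C)CCC2(C)C`, differs from compound 2 by 3-(aminomethyl)cyclohexyl in place of 4-methylphenyl on a saturated chain carbon bound to an amide-type nitrogen. Going by the values given here, the one measured step that bears on this position is a 1.6-fold higher number from compound 1 to compound 2 (0.21 log units; within the scatter), which swaps a substituted cyclohexyl for the 4-methylphenyl and stays within the scatter. Compound 3, carrying a cyclohexyl with a trifluoroacetamide-bearing methyl at that place, gives a number within the scatter of compound 2 as well. The shared core appears to carry the affinity, and the amide-side group has so far moved the number little. A free primary amine on the ring has not been tested, so the direction is uncertain; no step beyond the scatter is expected.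

Compound 4 is therefore estimated at 70 nM in this assay, with a range of 25 nM to 200 nM. The expected step is a 1.2-fold lower number from compound 2 to compound 4 (0.07 log units; within the scatter).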

Compound 4, inhibition constant: 174 nM
Estimate against measurement, compound 4: 2.5-fold (0.40 log units) below; the measured number falls inside the stated range.
By their numbers in this assay, from the lowest: compounds 1, 3 and 2 (each within the scatter of the next); then compound 4.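

In this assay, going by these compounds alone, this is the first change on a saturated chain carbon bound to an amide-type nitrogen to move the number beyond the scatter: 3-(aminomethyl)cyclohexyl gives a 2.1-fold higher number from compound 2 to compound 4 (0.32 log units; beyond the scatter) in place of 4-methylphenyl, and a 3.4-fold higher number from compound 1 to compound 4 (0.53 log units; beyond the scatter) in place of 4-(ethoxycarbonyl)cyclohexyl. The position therefore does respond to the group it carries, although both steps remain modest and run towards a higher number. Nothing available explains these steps.

The compounds shown leave open whether the steps follow the aminomethyl group or the saturated ring that carries it; a plain cyclohexyl and a 3-(aminomethyl)phenyl at this place would separate the two. Also open, as far as these compounds go, is how a carboxylic acid or a longer chain ending in an amine would read here.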